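A few compounds are considered here, and "the series" means these few. Any claim that something is new, unique, unknown or untested is made for them only; others in the source may bear on it.

Compound 1 `Cc1cccc(CN2CCN(C(=O)CN[C@H]3CCN(S(=O)(=O)Cc4ccccc4)C3)CC2)c1` was tested in a functional assay on K562 cells (Homo sapiens) for cytotoxicity, read by MTT assay, with a stated time of 48 h (a higher number here means a weaker inhibitor, a lower number a stronger inhibitor), where compound 1 gives 11300 nM. Within the data shown here, only one other number has been measured: compound 2 `O=C(CN[C@H]1CCN(S(=O)(=O)Cc2ccccc2)C1)N1CCN(Cc2ccc(F)cc2)CC1` in this assay gives 14300 nM. The step of a 1.3-fold higher number from compound 1 to compound 2 (0.10 log units; within the scatter) lies within the scatter, so compound 1 stands level with compound 2 rather than apart from it.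

Compound 3 `O=C(CN[C@H]1CCN(S(=O)(=O)Cc2ccccc2)C1)N1CCN(Cc2c(Cl)cccc2Cl)CC1` has not yet been measured in this assay. It differs from compound 1 in one place: 2,6-dichlorophenyl in place of 3-methylphenyl on a saturated chain carbon bound to an amine nitrogen in a ring. Among the measured compounds shown here, the single measured step that bears on this change is the one from compound 1 to compound 2, a 1.3-fold higher number from compound 1 to compound 2 (0.10 log units; within the scatter), which replaced the same 3-methylphenyl group at the same place on a saturated chain carbon bound to an amine nitrogen in a ring and produced no step beyond the scatter. For the measured compounds named here, no measured compound carries a 2,6-dichlorophenyl group, so nothing shows what that group does here.

On this basis the step from compound 1 to compound 3 is expected to be a 1.0-fold higher number from compound 1 to compound 3 (0.01 log units; within the scatter), nothing beyond the scatter. Compound 3 is therefore estimated at 11500 nM in this assay, with a range from 4000 nM to 35000 nM.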

Compound 3, half-maximal inhibitory concentration: 28400 nM
Compound 3: the middle estimate sits 2.5-fold (0.39 log units) below what was measured; low and high end bracket the measured number.
By their numbers in this assay, from the lowest: compounds 1, 2 and 3 (each within the scatter of the next, the first and the last beyond it).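

In this assay, among these compounds, the place on a saturated chain carbon bound to an amine nitrogen in a ring proves not to be wholly indifferent to the group it carries: 2,6-dichlorophenyl in place of 3-methylphenyl gives a 2.5-fold higher number from compound 1 to compound 3 (0.40 log units; beyond the scatter) and so the first step beyond the scatter in this short series, although a modest one. Set against the 4-fluorophenyl group of compound 2, the same group gives a 2.0-fold higher number from compound 2 to compound 3 (0.30 log units; within the scatter) and so stands level with it, which means that compound 3 stands apart from compound 1 alone and the three compounds do not fall into separate groups. Nothing measured here accounts for the step beyond the scatter, and these numbers cannot say whether the chlorine atoms, their number or their places carry it.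

As far as these compounds go, it remains open what an unsubstituted phenyl ring, a phenyl ring with a single chlorine, or a pyridine ring would give at this place. The compounds shown also leave open whether any group here, such as a carboxylic acid or a methoxy group on the ring, moves the number further than these changes do, and what changes elsewhere on the shared core would do.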